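The source may report more compounds than this note shows. Statements on the series, on what has been measured and on what is new or still open speak of the compounds shown alone.

In a functional assay on NCI-H23 cells (Homo sapiens) for antiproliferative activity, read by sulforhodamine B assay (a higher number here means a weaker inhibitor of growth, a lower number a stronger inhibitor of growth), compound 3 (`O=C(/C=C/c1ccc(O)cc1)c1c(O)cccc1OCCC1CCCCC1`) reads > 30000 nM, which is a limit of the assay and not a number. Compound 2 (`CC(C)=CCOc1cccc(O)c1C(=O)/C=C/c1ccc(O)cc1`) reads > 30000 nM, which is also a limit. Going by the values given here, compound 1 (`CC(C)(C)CCOc1cccc(O)c1C(=O)/C=C/c1ccc(C(=O)O)cc1`) gives a number, 4770 nM, but no measured step connects it with compound 4.

Compound 4 (`CC(C)CCOc1cccc(O)c1C(=O)/C=C/c1ccc(O)cc1`) differs from compound 3 in one place: isopropyl in place of cyclohexyl on a saturated chain carbon, two bonds along the chain from an oxygen on an aromatic ring. Put another way, 2-cyclohexylethoxy gives way to isopentyloxy.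

Among the compounds with values here, the only measured step that bears on this change is a step that the two limits leave unreadable from compound 2 to compound 3, and it has no readable size. The remaining evidence from compound 2 and compound 3 is the limit of > 30000 nM in this assay, at which 2 of the 3 values shown sit. Neither compound gives a measured number from which to size a shift, and nothing measured points to a gain in growth inhibition for compound 4. No step beyond the scatter is therefore expected in this assay, and no direction can be assigned. The expected change is a number no higher from compound 3 to compound 4 (the limit leaves the size open), and compound 4 will most likely also be reported only as a limit. For compound 4 the estimated value is 30000 nM, with an expected range from 12000 nM to 60000 nM.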

Compound 4, concentration for 50% growth inhibition: 12100 nM
For compound 4 the middle estimate is 2.5-fold (0.39 log units) above the measured one; the range from low to high includes it.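

In this assay, isopropyl in place of cyclohexyl on the saturated chain carbon, two bonds along the chain from the oxygen on the aromatic ring, gives an at least 2.4-fold lower number from compound 3 to compound 4 (0.39 log units; beyond the scatter), so this end of the chain can bring the read-out to a measurable number, which compounds 2 and 3 alone could not show. Isobutyl in place of 2-methylprop-1-en-1-yl gives an at least 2.4-fold lower number from compound 2 to compound 4 (0.39 log units; beyond the scatter), so the saturated isopentyloxy chain and the unsaturated chain of compound 2 are also separated, although the full size of both steps stays open. The step between compound 2 and compound 3 still cannot be read, and these two compounds remain tied to a shared limit of the assay: the limit of > 30000 nM in this assay, at which 2 of the 4 values shown sit.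

The compounds shown do not tell whether the gain in growth inhibition follows from the smaller isopropyl end itself or would also appear with a straight pentyl chain or a shorter ethoxy chain. Compound 1 differs from compound 4 in more than one place, so the effect of its carboxylic acid stays unseparated from that of its chain, and an amine at this position remains an open case.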